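Isopropoxy cut back to ethoxy on compound 3

A few compounds are considered here, and "the series" means these few. Any claim that something is new, unique, unknown or untested is made for them only; others in the source may bear on it.

- compound 1 `Cc1cc(-c2ncccn2)cc(C(=O)NNS(=O)(=O)c2ccccc2)c1F` gives 2.72 h 
- compound 2 `Cc1cc(-n2cccn2)cc(C(=O)NNS(=O)(=O)c2ccccc2)c1F` gives 1.25 h 
- compound 3 `Cc1cc(OC(C)C)cc(C(=O)NNS(=O)(=O)c2ccccc2F)c1` gives 0.5 h 
- compound 4 `CCOc1cc(C)cc(C(=O)NNS(=O)(=O)c2ccccc2F)c1` is still unmeasured

In an ADME assay on microsomes from liver (Homo sapiens) for metabolic stability, read by HPLC, using NADPH, with a stated time of 60 min, tested at 1 uM, in the presence of a further agent that is not named here (a higher number here means that the compound lasts longer, a lower number that the compound disappears faster), compound 3 has the lowest number of the three measured compounds, with compound 2 nearest to it and compound 1 furthest. The change to compound 4 is hydrogen in place of methyl on a saturated chain carbon bound to an oxygen on an aromatic ring and a saturated chain carbon and puts hydrogen in place of methyl on a saturated chain carbon bound to an oxygen on an aromatic ring and a saturated chain carbon, so isopropoxy becomes ethoxy. Going by the values given here, the only measured step (a 2.2-fold lower number from compound 1 to compound 2 (0.34 log units; beyond the scatter)) is modest and swaps a different group, so it bears on this change only loosely. Among the compounds with values here, no measured pair shows this change, so no step beyond the scatter is expected in this assay and no direction can be favoured. The expected step is small (a 1.1-fold higher number from compound 3 to compound 4 (0.04 log units; within the scatter)) and stays within that expectation. The estimate for compound 4 is 0.55 h with an expected range from 0.28 h to 1.1 h in this measurement.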

Compound 4, half-life in the Homo sapiens assay: 0.15 h
The estimate for compound 4 lay 3.7-fold (0.56 log units) above the measured number, outside the stated range (below it).
By their numbers in the Homo sapiens assay, from the lowest: compound 4; then compound 3; then compound 2; then compound 1.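

Cutting isopropoxy back to ethoxy gives, in the Homo sapiens assay, a 3.3-fold lower number from compound 3 to compound 4 (0.52 log units; beyond the scatter), with compound 3 at 0.5 h and compound 4 at 0.15 h, so a single methyl at this place on the chain is enough to shift the half-life beyond the scatter. In a physicochemical assay for solubility, read by nephelometry, measured as kinetic solubility, at pH 2 (on this read-out higher numbers stand for higher solubility and lower numbers for lower solubility), the same change gives no change at the digits printed from compound 3 to compound 4 (within the scatter), with compound 3 at 12.5 ug/mL and compound 4 at 12.5 ug/mL, so the two read-outs part ways here. Nothing measured here explains the shift.

On these data alone, whether a longer chain such as butoxy, or an amine at this place, would raise the half-life stays open. So does whether the step would hold on the core of compound 1.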